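The source may hold more compounds than are shown below. What is called first, only, known or untested is meant among the compounds shown, and "the series" means these compounds.

Compound 1 `CCCC[C@H](NC(=O)[C@H](CCCCN)NC(=O)[C@H](CCCNC(=N)N)NC(=O)/C=C/c1ccccc1)C(N)=O` gives 1.26 10^-6 cm/s in an ADME assay for permeability, using PAMPA; a higher number here means that the compound crosses the layer faster, a lower number that the compound crosses the layer more slowly. Compound 2 `CCCC[C@H](NC(=O)[C@H](CCCCN)NC(=O)[C@H](CCCNC(=N)N)NC(=O)c1ccc(/C=C/C(N)=O)cc1)C(N)=O` is recorded in this assay only as "impermeable" (no number reported), so no single number places it against compound 1. Compound 3 `CCCC[C@H](NC(=O)[C@H](CCCCN)NC(=O)[C@H](CCCNC(=N)N)NC(=O)c1ccccc1)C(N)=O` differs from compound 2 by hydrogen in place of 2-carbamoylethenyl on an aromatic carbon, the 4-(2-carbamoylethenyl)phenyl becoming phenyl. Among the compounds with values here, no measured step between two numbered compounds is available, so the outlook rests on compound 1 at 1.26 10^-6 cm/s, which shares the core with compound 2 and compound 3. Compound 3 is expected to show an apparent permeability of 1 10^-6 cm/s, within 0.3 10^-6 cm/s to 3 10^-6 cm/s, with some chance that only a limit is reported.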

Compound 3, apparent permeability: "impermeable" (no number reported)
Nothing numeric was reported for compound 3, and the estimate cannot be compared.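

In this assay compound 2 and compound 3 are both recorded only as "impermeable", with no number, so no step can be read between them. As far as these compounds go, how far either lies from compound 1 remains open, and no evidence bears on the result.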